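Swapping a Triazole for a Tetrazole on the Sulfur

This account rests on a few compounds, and the source may have more. Where it says the series, first, only, none or still open, it means among the compounds named here.

Three measured compounds share one core. In a functional assay on C6 cells (Rattus norvegicus) for cytotoxicity, read by MTT assay, with a stated time of 24 h, tested at 100 ug/mL (on this read-out higher numbers stand for a weaker effect at the one concentration tested and lower numbers for a stronger effect), compound 1 `Cn1nnnc1SCC(=O)N/N=c1/scc(-c2ccccc2)n1-c1ccccc1` gives 38.8%, compound 2 `Cn1cnnc1SCC(=O)N/N=c1/scc(-c2ccc(C#N)cc2)n1-c1ccccc1` gives 55.2% and compound 3 `Cc1nnc(SCC(=O)N/N=c2/scc(-c3ccc(F)cc3)n2-c2ccccc2)s1` gives 34.9%. Compound 2 stands highest of the three, so it shows the weakest effect; compound 1 lies beyond the scatter below it, and compound 3 further still. Compound 4 `Cn1nnnc1SCC(=O)N/N=c1/scc(-c2ccc(C#N)cc2)n1-c1ccccc1` is not yet measured in this assay. It differs from compound 2 in one place: 1-methyl-1H-tetrazol-5-yl in place of 4-methyl-4H-1,2,4-triazol-3-yl on a sulfur. Among the measured compounds shown here, no measured pair differs only in this way. Compound 1 carries the same entering ring but differs from compound 4 in a second place too, so it cannot define the step. A modest downward step is expected, a number 8.2 percentage points lower from compound 2 to compound 4 (within the scatter), possibly within the scatter. Compound 4 is estimated at 47%, with a range from 30% to 64%.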

Compound 4, a percentage reported as activity, at one concentration (the size of the read-out at that concentration, not a potency): 30.9%
Estimate against measurement, compound 4: 16.1 percentage points above; the measured number falls inside the stated range.
By their numbers in this assay, from the lowest: compounds 4, 3 and 1 (each within the scatter of the next); then compound 2.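

In this assay the swap to 1-methyl-1H-tetrazol-5-yl from 4-methyl-4H-1,2,4-triazol-3-yl on the sulfur gives a number 24.3 percentage points lower from compound 2 to compound 4 (beyond the scatter) and thus, on its own, a stronger effect at this position. Cyano in place of hydrogen on an aromatic carbon, with the 1-methyl-1H-tetrazol-5-yl kept, gives a number 7.9 percentage points lower from compound 1 to compound 4 (within the scatter) and so no clear change. Nothing measured here says why the ring swap acts this way. On these data alone, whether the same swap holds in compounds without the cyano remains open. So does the effect of a different group on the sulfur, such as an amine or a longer chain.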